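The compounds below may be only part of what the source reports. "The series", "measured", "known", "first", "only" and "open" are said of these compounds alone.

Of the compounds shown here, three have so far been measured in a functional assay on HCT-116 cells (Homo sapiens) for inhibition, read by MTT assay, with a stated time of 48 h; on this read-out higher numbers stand for weaker inhibition and lower numbers for stronger inhibition. Compound 1 `COc1cc(NCc2ccc(Br)cc2)cc(OC)c1OC` gives > 80000 nM, and this is a limit of the assay, not a number. Compound 2 `COc1cc(NCc2cccc(O)c2)cc(OC)c1OC` gives 67700 nM, the higher of the two actual numbers, while compound 3 `C/C=C/C(=O)N(Cc1cccc(O)c1)c1cc(OC)c(OC)c(OC)c1` gives 6700 nM.

Compound 4 `COc1cc(NCc2ccc(C)cc2)cc(OC)c1OC` has yet to be measured. It differs from compound 2 at one place: 4-methylphenyl in place of 3-hydroxyphenyl on a saturated chain carbon bound to a nitrogen on an aromatic ring. Thus 4-methylphenyl stands in place of 3-hydroxyphenyl, on a saturated chain carbon bound to a nitrogen on an aromatic ring.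

One measured step changes this same place, an at least 1.1-fold lower number from compound 1 to compound 2 (0.07 log units; that floor lies within the scatter), and it is the closer guide. The other step, a 10-fold lower number from compound 2 to compound 3 (1.00 log units; beyond the scatter), is larger, but it puts (prop-1-en-1-yl)carbonyl in place of hydrogen on a nitrogen on an aromatic ring, a change that compound 4 does not carry. It therefore says little about the present swap.

Going by the first step alone, no change beyond the scatter is expected in this assay, and neither direction is favoured. The estimated change is a 1.0-fold higher number from compound 2 to compound 4 (0.01 log units; within the scatter). For compound 4 the expected value is 70000 nM, with an estimated range from 30000 nM to 140000 nM.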

Compound 4, half-maximal inhibitory concentration: > 80000 nM
Compound 4 gave a limit, no number (the forecaster's own chance of this, stated with the estimate: 45%); middle value at least 1.1-fold (0.05 log units) away from the limit.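

In this assay compound 4 gives > 80000 nM, which is a limit of the assay and not a number. The swap of 3-hydroxyphenyl for 4-methylphenyl gives an at least 1.1-fold higher number from compound 2 to compound 4 (0.07 log units; that floor lies within the scatter), and since that floor lies within the scatter, losing the hydroxyl does not demonstrably weaken inhibition, though the true size of the step may be larger. This place has now held 4-bromophenyl, 3-hydroxyphenyl and 4-methylphenyl without the value leaving the top of the range shown, and the step between compound 1 and compound 4 cannot be read, so these results give no order among the three groups, with the ceiling set by the limit: the limit of > 80000 nM in this assay, at which 2 of the 4 values shown sit.

Going by these compounds, it remains open how far compound 1 and compound 4 lie past that limit, and so whether the hydroxyl of compound 2 contributes anything real. Also open, on these data alone, are whether an amine or a carboxylic acid on this phenyl ring, or a longer chain at the saturated carbon, would bring a clear change, and whether the (prop-1-en-1-yl)carbonyl on the nitrogen of compound 3 would lower the number with 4-methylphenyl in place.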